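Amino for Bromo on the Benzamide of Compound 3

A few compounds are considered here, and "the series" means these few. Any claim that something is new, unique, unknown or untested is made for them only; others in the source may bear on it.

Among the measured compounds shown here, in an assay on isolated protein for inhibition of Rho-associated protein kinase 1 (Homo sapiens), read by scintillation counting, radiometric assay and 33P incorporation, with a stated time of 40 min, in the presence of a further agent that is not named here (on this read-out higher numbers stand for weaker inhibition and lower numbers for stronger inhibition), compound 3 `O=C(COc1ccc2c(=O)ccoc2c1)Nc1cccc(NC(=O)c2ccc(Br)cc2)c1` gives 303 nM, the only number among the three measured compounds. Compound 1 `CN(C)c1ccc(C(=O)Nc2cccc(NC(=O)COc3ccc4c(c3)CCC(=O)N4)c2)cc1` reaches only the assay limit, > 10000 nM. Compound 2 `CN(C)c1ccc(C(=O)Nc2cccc(NC(=O)COc3ccc4occc(=O)c4c3)c2)cc1` likewise stops at the limit, > 10000 nM. Both sit at the limit of > 10000 nM in this assay, at which 2 of the 3 values shown sit, so the step that the two limits leave unreadable from compound 1 to compound 2 cannot be read. Compound 4 `Nc1ccc(C(=O)Nc2cccc(NC(=O)COc3ccc4c(=O)ccoc4c3)c2)cc1` differs from compound 3 by amino in place of bromo on an aromatic carbon. For the measured compounds named here, no measured step touches this position: the one step recorded concerns another part of the molecule and is unreadable. The account therefore expects no shift beyond the usual scatter. The expected step of a 1.3-fold higher number from compound 3 to compound 4 (0.12 log units; within the scatter) is an estimate carried over from compound 3. Compound 4 is expected to give 400 nM, within 100 nM to 2000 nM.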

Compound 4, half-maximal inhibitory concentration: 802 nM
Compound 4: the middle estimate sits 2.0-fold (0.30 log units) below what was measured; the measured number falls inside the stated range.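

In this assay, among the compounds shown here, putting amino in place of bromo on the aromatic carbon para to a large group gives a 2.6-fold higher number from compound 3 to compound 4 (0.42 log units; beyond the scatter), the first readable step at this position. The position is therefore not silent: exchanging this single heavy atom moves the number, yet the amino compound still gives a measured value rather than a limit. Nothing measured here accounts for the shift. On these data alone, whether chloro, methoxy or a carboxylic acid at this position would move the number further, and in which direction, stays open.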